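A few compounds are considered here, and "the series" means these few. Any claim that something is new, unique, unknown or untested is made for them only; others in the source may bear on it.

Compound 1 `Fc1ccc(-c2ccc3c(NCCCNCc4ccco4)ccnc3c2)cc1` gives 32000 nM. Compound 2 `COc1cccc(CNCCCNc2ccnc3cc(-c4ccc(C(F)(F)F)cc4)ccc23)c1O` gives 32000 nM. Compound 3 `FC(F)(F)c1ccc(-c2ccc3c(NCCCNCc4ccco4)ccnc3c2)cc1` gives 32000 nM.

In a physicochemical assay for solubility, with a stated time of 18 h, at pH 7.4 (a lower number here means a less soluble compound, a higher number a more soluble compound), compound 2 stands level with compound 1 and compound 3, all three within the scatter of one another. Within the data shown here, the only measured steps are no change at the digits printed from compound 1 to compound 3 (within the scatter) and no change at the digits printed from compound 2 to compound 3 (within the scatter). Compound 4 `COc1cccc(CNCCCNc2ccnc3cc(-c4cccc5ccccc45)ccc23)c1O` differs from compound 2 by naphthalen-1-yl in place of 4-(trifluoromethyl)phenyl on an aromatic carbon. Among the measured compounds shown here, of the measured steps, only the one from compound 1 to compound 3 touches the same place, and it was flat; the other concerns a different end of the molecule. Nothing here indicates that a change at this position moves solubility, so compound 4 is expected to show no change at the digits printed from compound 2 to compound 4 (within the scatter), a step no larger than the scatter. Compound 4 is therefore estimated at 32000 nM, in the range 12000 nM to 64000 nM.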

Compound 4, solubility: 32000 nM
The estimate for compound 4 equals the measured number at the digits printed; the range from low to high includes it.
By their numbers in this assay, from the lowest: compounds 1, 2, 3 and 4 (each within the scatter of the next).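

In this assay, naphthalen-1-yl in place of 4-(trifluoromethyl)phenyl gives no change at the digits printed from compound 2 to compound 4 (within the scatter). The earlier step at this place only exchanged one substituent on the phenyl ring, whereas this one replaces the whole group, so that a second six-membered aromatic ring enters and the fluorine leaves. No evidence is available that bears on this result. Open, from the compounds shown here alone, is whether a phenyl ring carrying an amine or a carboxylic acid at this place would give a different reading, and whether naphthalen-1-yl behaves the same with furan-2-yl on the chain.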